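Alkyl to aryl swap on the amine of compound 3

This account rests on a few compounds, and the source may have more. Where it says the series, first, only, none or still open, it means among the compounds named here.

Within the data shown here, compound 3 `CN(c1ncnc2c1ncn2Cc1ccccc1)C1CCCC1` is one of three compounds measured in a functional assay on the whole organism for inhibition, with Rattus norvegicus as the target, in the maximal electroshock model, at a dose of 25 mg/kg by the intraperitoneal route; a higher number here means more inhibition at the dose given (going by the name of the read-out), a lower number less inhibition. In this assay compound 3 gives 17%. It stands level with compound 2 `CC(C)N(C)c1ncnc2c1ncn2Cc1ccccc1`, which gives 17%, and these two are together the lowest of the three numbers. The furthest is compound 1 `C[C@@H](c1ccccc1)n1cnc2c(N(C)C)ncnc21`, which gives 33%, a gap beyond the scatter. Among the measured compounds shown here, the one measured step, no change at the digits printed from compound 2 to compound 3 (within the scatter), swaps one alkyl group for another on the same nitrogen and shows no change.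

Compound 4 `c1ccc(Cn2cnc3c(Nc4ccccc4)ncnc32)cc1` has not yet been measured. It differs from compound 3 by anilino in place of cyclopentyl(methyl)amino on an aromatic carbon. For the measured compounds named here, the measured step from compound 2 to compound 3 bears on it only as an alkyl-for-alkyl exchange at the same place, and it was flat; no measured step shows an aryl group with a hydrogen-bond donor entering here. The expected step is therefore a number 3 percentage points higher from compound 3 to compound 4 (within the scatter), no change beyond the scatter, with wide uncertainty. For compound 4 the estimate in this assay is 20%, in the range 5% to 40%.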

Compound 4, a percentage reported as inhibition, in the whole organism at one dose (the size of the read-out at that dose, not a potency): 0%
For compound 4 the middle estimate is 20 percentage points above the measured one; the whole stated range lies above it.
By their numbers in this assay, from the lowest: compound 4; then compounds 2 and 3 (each within the scatter of the next); then compound 1.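

The flat alkyl exchange (no change at the digits printed from compound 2 to compound 3 (within the scatter)) left open whether this position responds at all, but anilino on this aromatic carbon does move the read-out in this assay: a number 17 percentage points lower from compound 3 to compound 4 (beyond the scatter), and likewise a number 17 percentage points lower from compound 2 to compound 4 (beyond the scatter). The change keeps the count of heavy atoms while replacing a five-membered non-aromatic ring of carbon with a six-membered aromatic ring and adding a hydrogen-bond donor, so these two differences enter together and the step cannot separate them. Nothing measured beyond these read-outs bears on why the number falls.

The compounds shown leave open which of the two differences carries the step. Methyl(phenyl)amino at this place would keep the aromatic ring without the hydrogen-bond donor, while cyclohexylamino would keep the donor without the aromatic ring.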